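Dipropylamino in place of (5-chloro-2-methylphenyl)amino: an estimate

The source may report more compounds than this note shows. Statements on the series, on what has been measured and on what is new or still open speak of the compounds shown alone.

Three compounds have been measured in a functional assay on CHO-K1 cells for antagonist activity at transient receptor potential cation channel subfamily V member 1 (Homo sapiens), read by FLIPR; on this read-out lower numbers stand for stronger inhibition and higher numbers for weaker inhibition:
Compound 1 `CC(C(=O)NCc1ccc(C(F)(F)F)nc1NCC1CCN(C(=O)OC(C)(C)C)CC1)c1ccc(NS(C)(=O)=O)c(F)c1` gives 19.3 nM
Compound 2 `Cc1ccc(Nc2nc(C(F)(F)F)ccc2CNC(=O)C(C)c2ccc(NS(C)(=O)=O)c(F)c2)cc1C` gives 39.3 nM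
Compound 3 `Cc1ccc(Cl)cc1Nc1nc(C(F)(F)F)ccc1CNC(=O)C(C)c1ccc(NS(C)(=O)=O)c(F)c1` gives 14 nM

Compound 3 has the lowest number of the three, though compound 1 sits within the scatter of it; only compound 2 is clearly apart. The one single-point step shown is a 2.8-fold lower number from compound 2 to compound 3 (0.45 log units; beyond the scatter), a modest change when one substituted phenyl amine replaces another at the same place.

Compound 4 `CCCN(CCC)c1nc(C(F)(F)F)ccc1CNC(=O)C(C)c1ccc(NS(C)(=O)=O)c(F)c1` differs from compound 3 by dipropylamino in place of (5-chloro-2-methylphenyl)amino on an aromatic carbon. Among the compounds with values here, no measured step exchanges an aromatic amine for an open-chain dialkylamine here, so the step from compound 2 to compound 3 bears only loosely on it. For compound 4 a weaker number is expected, a 5.7-fold higher number from compound 3 to compound 4 (0.76 log units; beyond the scatter), giving an estimated 80 nM with a range from 20 nM to 400 nM in this assay.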

Compound 4, inhibition constant: 0.2 nM
The estimate for compound 4 lay 400-fold (2.60 log units) above the measured number, outside the stated range (below it).
By their numbers in this assay, from the lowest: compound 4; then compounds 3 and 1 (each within the scatter of the next); then compound 2.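

Replacing the aryl amine with dipropylamino, which has no ring and no hydrogen-bond donor, gives a 70-fold lower number from compound 3 to compound 4 (1.85 log units; beyond the scatter) and a 200-fold lower number from compound 2 to compound 4 (2.29 log units; beyond the scatter) as well. Both steps are large beside a 2.8-fold lower number from compound 2 to compound 3 (0.45 log units; beyond the scatter) between two phenyl amines, so among these compounds the kind of amine at this place counts for more than the substituents on the phenyl ring. Nothing available explains why the number falls so far.

From the compounds shown here alone, it remains open whether both propyl chains are needed. Propylamino, diethylamino or pyrrolidine at this place would separate chain length from the loss of the donor.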